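The source may report more compounds than this note shows. Statements on the series, on what has been measured and on what is new or still open speak of the compounds shown alone.

Working notes on the series. In a functional assay on the whole organism for inhibition, with Rattus norvegicus as the target, with a stated time of 5 min (a higher number here means that more compound is needed for the effect, a lower number that less compound is needed), compound 1 (`O=C(O)CCCOc1cccc(/C=C/c2ccc3cc(Cl)ccc3n2)c1`) stands at 1.5 mg/kg and belongs to the upper pair of the three measured numbers. Compound 2 (`COC(=O)COc1cccc(/C=C/c2ccc3ccccc3n2)c1`) at 2 mg/kg lies within the scatter of compound 1. Compound 3 (`O=C(O)CCSC(SCCC(=O)O)c1cccc(/C=C/c2ccc3ccc(Cl)cc3n2)c1`) at 0.1 mg/kg lies beyond the scatter of compound 1, with the lower number, so less of it is needed for the effect.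

The next compound to read is compound 4 (`O=C(O)CCCOc1cccc(/C=C/c2ccc3cc(Cl)c(Cl)cc3n2)c1`). It departs from compound 1 in one place: chloro in place of hydrogen on an aromatic carbon, ortho to a chloro group (chloro in place of hydrogen on an aromatic carbon). The rest of the structure, including the side chain that ends in the acid, stays as it is in compound 1.

For the measured compounds named here, no two measured compounds differ in one place only, so the data hold no direct measure of a change of this kind. Going by the values given here, only three measured compounds bear on the expectation, and they leave it loose. In this assay no step beyond the scatter is expected, with a slight lean towards a lower number. The expected move (a 1.3-fold lower number from compound 1 to compound 4 (0.10 log units; within the scatter)) is small. For compound 4 the estimated value is 1.2 mg/kg with an expected range from 0.4 mg/kg to 3.5 mg/kg in this measurement.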

Compound 4, dose for half-maximal effect: 0.5 mg/kg
For compound 4 the middle estimate is 2.4-fold (0.38 log units) above the measured one; measured number inside the range.
By their numbers in this assay, from the lowest: compound 3; then compound 4; then compounds 1 and 2 (each within the scatter of the next).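

In this assay, for the compounds shown here, chloro in place of hydrogen on an aromatic carbon ortho to a chloro group gives a 3.0-fold lower number from compound 1 to compound 4 (0.48 log units; beyond the scatter), the first step between two measured compounds that differ in one place. This position, meta to a fused ring and para to a fused ring, therefore takes a second chloro group, a single added heavy atom with no hydrogen-bond donors or acceptors, and less compound is needed for the effect while the side chain ending in the acid stays as it is. No measurement at hand bears on the reason for this step.

The compounds shown leave open whether the step belongs to chloro as such or would also appear with fluoro, methyl or methoxy on the same aromatic carbon. They also leave open whether the new chloro group needs the chloro group already present in compound 1, and whether the same step would hold with the methyl ester side chain of compound 2 or the sulfur-linked diacid side chain of compound 3.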